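The source may hold more compounds than are shown below. What is called first, only, known or untested is meant among the compounds shown, and "the series" means these compounds.

Measured compounds:
- compound 1, `O=C(Nc1cccc(-n2cc(-c3ccncc3)c(-c3ccc(Cl)c(O)c3)n2)c1)Nc1cccc(C(F)(F)F)c1`: 948 nM
- compound 2, `COc1cc(-c2nn(-c3cccc(NC(=O)Nc4cc(C(F)(F)F)cc(C(F)(F)F)c4)c3)cc2-c2ccncc2)ccc1Cl`: 250 nM

Of the compounds shown here, two have been tested in a functional assay on PC-3 cells (Homo sapiens) for inhibition, read by sulforhodamine B assay, with a stated time of 48 h; a lower number here means a stronger inhibitor of growth, a higher number a weaker inhibitor of growth. Compound 1 gives 948 nM, the highest of the two numbers, so it is the weaker growth inhibitor of the pair. Compound 2 gives 250 nM, a lower number that lies beyond the usual scatter of this assay; the two compounds differ in several places at once, so the two values show only that gap and nothing about any single change.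

Compound 3, `O=C(Nc1cccc(-n2cc(-c3ccncc3)c(-c3ccc(Cl)c(O)c3)n2)c1)Nc1ccc(Cl)c(Cl)c1`, has not been measured. It differs from compound 1 in one place: 3,4-dichlorophenyl in place of 3-(trifluoromethyl)phenyl on an amide-type nitrogen. Within the data shown here, no measured pair shows this change on its own, so the step is expected to be small, in no clear direction, and within the scatter of this assay; the estimated step is a 1.2-fold higher number from compound 1 to compound 3 (0.06 log units; within the scatter). On that basis compound 3 is expected to give about 1100 nM, in a range from 400 nM to 3000 nM.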

Compound 3, concentration for 50% growth inhibition: 834 nM
For compound 3 the middle estimate is 1.3-fold (0.12 log units) above the measured one; the range from low to high includes it.
By their numbers in this assay, from the lowest: compound 2; then compounds 3 and 1 (each within the scatter of the next).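

Among these compounds, this is the first step in which only one place changes, so it gives a first direct reading of the group on the amide-type nitrogen. In this assay, 3,4-dichlorophenyl in place of 3-(trifluoromethyl)phenyl gives a 1.1-fold lower number from compound 1 to compound 3 (0.06 log units; within the scatter) and so the two groups cannot be told apart in this test of growth inhibition. Nothing measured here bears on why these two groups give such similar numbers.

What a phenyl ring carrying an amine or a carboxylic acid would do at this place remains open, since both groups shown are halogen-bearing phenyl rings. Also open, on these data alone, is whether the same near-equality would hold on a core that differs elsewhere, as one step on the core of compound 1 cannot say.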